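Swapping the phenoxy ring substituent in a pyrazole amide series

The compounds below may be only part of what the source reports. "The series", "measured", "known", "first", "only" and "open" are said of these compounds alone.

Measured compounds:
- compound 1 `Cc1nn(Cc2ccccc2)c(C)c1NC(=O)c1ccc(COc2ccccc2)cc1`: 10000 nM
- compound 2 `Cc1nn(Cc2cccc(C(=O)N(C)C)c2)c(C)c1NC(=O)c1ccc(COc2ccccc2)cc1`: 6400 nM
- compound 3 `CNC(=O)c1cccc(Cn2nc(C)c(NC(=O)c3ccc(COc4ccc(C)cc4)cc3)c2C)c1`: 2600 nM

All three compounds were tested in a functional assay on MIA PaCa-2 cells (Homo sapiens) for antiproliferative activity, read by MTT assay, with a stated time of 72 h; a lower number here means that less compound is needed, a higher number that more compound is needed for the effect. In this assay compound 3 gives the lowest number of the three, with compound 2 standing a step above it and compound 1 the furthest away; both of these gaps lie beyond the scatter. Compound 4 `CNC(=O)c1cccc(Cn2nc(C)c(NC(=O)c3ccc(COc4cccc(C(F)(F)F)c4)cc3)c2C)c1` has not yet been measured. It differs from compound 3 in one place: 3-(trifluoromethyl)phenyl in place of 4-methylphenyl on an oxygen on a saturated carbon.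

For the measured compounds named here, the only measured step that changes a single group, a 1.6-fold lower number from compound 1 to compound 2 (0.19 log units; within the scatter), concerns a different part of the molecule and lies within the scatter, so it says little about the phenoxy ring. Going by the values given here, compounds 2 and 3 differ in two places at once, so their values show only that a change including the methyl on the phenoxy ring went with a lower number. Among the compounds with values here, with no step that bears directly on this change, compound 4 is expected to stay close to compound 3, and the step of a 1.2-fold lower number from compound 3 to compound 4 (0.07 log units; within the scatter) is estimated to fall within the scatter. Compound 4 is therefore estimated at 2200 nM, with a range from 600 nM to 8000 nM.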

Compound 4, half-maximal effective concentration: 2300 nM
Beside the measured number, compound 4's estimate is 1.0-fold (0.02 log units) below it, and the stated range covers the measured number.
By their numbers in this assay, from the lowest: compounds 4 and 3 (each within the scatter of the next); then compounds 2 and 1 (each within the scatter of the next).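

In this assay, the change from 4-methylphenyl to 3-(trifluoromethyl)phenyl on the oxygen gives a 1.1-fold lower number from compound 3 to compound 4 (0.05 log units; within the scatter). This is the first step among these compounds that changes only the phenoxy ring, and it shows that this position accepts a group of 10 heavy atoms in place of one of 7, with a different substituent on the ring, without a change that stands out from the scatter. Nothing measured here speaks to why the two rings read alike.

From the compounds shown here alone, both rings carry only a methyl or a trifluoromethyl substituent, so it remains open whether an amine or a carboxylic acid on the phenoxy ring would give a different number. Going by these compounds, it is also open whether the ring could give way to a simple longer chain on the oxygen.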